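A few compounds are considered here, and "the series" means these few. Any claim that something is new, unique, unknown or untested is made for them only; others in the source may bear on it.

Compound 1 `COc1cc(C[C@H]2C(=O)OC[C@@H]2Cc2ccc(OC)c(OC)c2)ccc1N` is the starting point of this account. In an ADME assay on A549 cells (Homo sapiens) for cytotoxicity, read by MTT assay, with a stated time of 4 days (a higher number here means a weaker inhibitor, a lower number a stronger inhibitor), compound 1 gives > 50000 nM, a value that is a limit of the assay. Compound 2 `COc1cc(C[C@H]2C(=O)OC[C@@H]2Cc2ccc(OC)c(OC)c2)ccc1NC(=O)c1ccccc1` carries a benzoyl in place of hydrogen on a nitrogen on an aromatic ring. In this assay compound 2 gives > 50000 nM, which is also a limit. Compound 3 `CCC(=O)Nc1ccc(C[C@H]2C(=O)OC[C@@H]2Cc2ccc(OC)c(OC)c2)cc1OC` carries a propanoyl in place of hydrogen on a nitrogen on an aromatic ring. In this assay compound 3 gives > 50000 nM, again a limit. The steps between them, a step that the two limits leave unreadable from compound 1 to compound 2, a step that the two limits leave unreadable from compound 1 to compound 3 and a step that the two limits leave unreadable from compound 2 to compound 3, therefore cannot be sized, because of the limit of > 50000 nM in this assay, at which 3 of the 3 values shown sit.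

Compound 4 `COc1cc(C[C@H]2C(=O)OC[C@@H]2Cc2ccc(OC)c(OC)c2)ccc1Nc1ccc(F)cc1` differs from compound 1 in one place: 4-fluorophenyl in place of hydrogen on a nitrogen on an aromatic ring. Going by the values given here, the steps that bear on it are the two other substitutions on that same nitrogen, from compound 1 to compound 2 and from compound 1 to compound 3, and neither could be read. Nothing in these three values points to a direction for compound 4, so the expectation is that compound 4 also sits at the limit. Compound 4 is thus estimated at 70000 nM, with a range from 25000 nM to 250000 nM. That estimate corresponds to an expected step that the limit leaves unreadable from compound 1 to compound 4.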

Compound 4, half-maximal inhibitory concentration: > 50000 nM
Compound 4 ended at the assay's limit; the forecaster's own chance of this, stated with the estimate: 80%; the middle value lies beyond the limit too.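

In this assay, going by these compounds alone, compound 4 gives > 50000 nM as a limit of the assay, so no step among compound 1, compound 2, compound 3 and compound 4 can be read. The compounds shown leave open how far beyond the limit each one lies, and whether any substitution on that nitrogen changes the read-out in this assay at all.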